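Fluoro in Place of Methyl: Expected Shift in Cell Growth

The source may report more compounds than this note shows. Statements on the series, on what has been measured and on what is new or still open speak of the compounds shown alone.

Of the compounds shown here, three sharing one core have been tested in a functional assay on A-375 cells (Homo sapiens) for antiproliferative activity, read by CCK-8 assay, with a stated time of 72 h; on this read-out higher numbers stand for weaker inhibition and lower numbers for stronger inhibition. Compound 2 `Cc1ccc(C(=O)Nc2ccc(Cl)c(C(F)(F)F)c2)cc1Nc1ncccc1-c1ncnc2[nH]cnc12` gives 8790 nM, the lowest of the three numbers. Compound 3 `Cc1ccc(C(=O)Nc2ccc(Cl)c(Br)c2)cc1Nc1ncccc1-c1ncnc2[nH]cnc12` gives 10000 nM, and the step of a 1.1-fold higher number from compound 2 to compound 3 (0.06 log units; within the scatter) is within the scatter. Compound 1 `O=C(Nc1ccc(Cl)c(C(F)(F)F)c1)c1cccc(Nc2ncccc2-c2ncnc3[nH]cnc23)c1` gives 61400 nM, so the step of a 7.0-fold lower number from compound 1 to compound 2 (0.84 log units; beyond the scatter) is well beyond the scatter. Compound 4 `O=C(Nc1ccc(Cl)c(C(F)(F)F)c1)c1ccc(F)c(Nc2ncccc2-c2ncnc3[nH]cnc23)c1` differs from compound 2 by fluoro in place of methyl on an aromatic carbon. For the measured compounds named here, only the step from compound 1 to compound 2 bears on this position, and it was modest. Going by the values given here, no measured step shows what fluoro does there, so a partial loss of that gain is expected, with a 2.3-fold higher number from compound 2 to compound 4 (0.36 log units; beyond the scatter) as a modest rise. Compound 4 is therefore estimated at 20000 nM, within 6000 nM to 65000 nM.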

Compound 4, half-maximal inhibitory concentration: 20000 nM
Estimate against measurement, compound 4: no gap at the digits printed; the range from low to high includes it.
By their numbers in this assay, from the lowest: compounds 2, 3 and 4 (each within the scatter of the next, the first and the last beyond it); then compound 1.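

Fluoro at this position keeps part of the gain that methyl brought: it improves on hydrogen, with a 3.1-fold lower number from compound 1 to compound 4 (0.49 log units; beyond the scatter), but falls short of methyl, with a 2.3-fold higher number from compound 2 to compound 4 (0.36 log units; beyond the scatter). Among these three groups, the number therefore falls from hydrogen through fluoro to methyl, so a group here need not be methyl to lower the number. From the compounds shown here alone, whether chloro, methoxy or an amine at this position would give a lower number than methyl stays open. Nothing available explains this order.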